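Swapping a fluorophenyl for a fluoropyridyl on a chalcone scaffold

This account rests on a few compounds, and the source may have more. Where it says the series, first, only, none or still open, it means among the compounds named here.

Measured compounds:
compound 1 `COc1ccc(/C=C/C(=O)c2ccccc2-c2ccc(F)cc2)cc1OC`: 440 nM
compound 2 `COc1ccc(/C=C/C(=O)c2ccccc2-c2ccc(F)nc2)cc1OC`: 1200 nM
compound 3 `COc1ccc(C(=O)/C=C/c2ccccc2-c2ccc(F)cc2)cc1`: 8200 nM

In a functional assay on A549 cells (Homo sapiens) for antiproliferative activity, read by sulforhodamine B assay, with a stated time of 48 h (a higher number here means a weaker inhibitor, a lower number a stronger inhibitor), compound 1 gives 440 nM and compound 2 gives 1200 nM. The change between them is 6-fluoropyridin-3-yl in place of 4-fluorophenyl on an aromatic carbon; it produced a 2.7-fold higher number from compound 1 to compound 2 (0.44 log units; beyond the scatter). Compound 3 gives 8200 nM in this assay, the highest of the three numbers. How the core of compound 3 differs from the core of compound 1 is not broken down here. Compound 4 `COc1ccc(C(=O)/C=C/c2ccccc2-c2ccc(F)nc2)cc1` is not yet measured; it differs from compound 3 by 6-fluoropyridin-3-yl in place of 4-fluorophenyl on an aromatic carbon, the same change as before, at a place described in the same words. Going by the values given here, compound 4 is expected to show a 2.4-fold higher number from compound 3 to compound 4 (0.39 log units; beyond the scatter) in this assay, a step of about the size seen from compound 1 to compound 2, because a 2.7-fold higher number from compound 1 to compound 2 (0.44 log units; beyond the scatter) is the only guide available. Compound 4 is therefore estimated at 20000 nM, within 7000 nM to 60000 nM.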

Compound 4, half-maximal inhibitory concentration: > 50000 nM
Compound 4 gave a limit, no number (the forecaster's own chance of this, stated with the estimate: 15%); at least 2.5-fold (0.39 log units) between middle value and limit.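

In this assay, compound 4 gives > 50000 nM, which is a limit of the assay and not a number. Carried to the core of compound 3, the swap of 4-fluorophenyl for 6-fluoropyridin-3-yl gave an at least 6.0-fold higher number from compound 3 to compound 4 (0.78 log units; beyond the scatter), the same direction as on the core of compound 1. Whether the size of the step carries over as well remains unsettled: the same change on two cores in this assay, a 2.7-fold higher number (0.44 log units; beyond the scatter) from compound 1 to compound 2 and an at least 6.0-fold higher number (0.78 log units; beyond the scatter) from compound 3 to compound 4; the limit leaves it open whether they differ

The compounds shown leave open where compound 4 truly lies beyond its limit and whether the same direction would hold on a further core. They also leave open how the series would respond if an amine or a carboxylic acid replaced the fluorine on this ring.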